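Benzylic amino ester versus methoxymethyl on the shared core

The compounds below may be only part of what the source reports. "The series", "measured", "known", "first", "only" and "open" are said of these compounds alone.

Measured in a functional assay on MCF7 cells (Homo sapiens) for cytotoxicity, read by neutral red uptake, with a stated time of 3 days; on this read-out higher numbers stand for weaker inhibition and lower numbers for stronger inhibition:
compound 1, `CCCCc1c(F)c(N)c2c(=O)cc(-c3ccc(N)c(F)c3)oc2c1F`: 8800 nM
compound 2, `CCCCCCc1c(F)c(N)c2c(=O)cc(-c3ccc(N)c(F)c3)oc2c1F`: > 10000 nM
compound 3, `CN(C)CC(=O)OCc1c(F)c(N)c2c(=O)cc(-c3ccc(N)c(F)c3)oc2c1F`: 26 nM

Compound 2 gives only a limit, (the limit of > 10000 nM in this assay, at which 1 of the 3 values shown sits). Compound 3 stands at the lowest number of the two that are numbers, with compound 1 the nearest, and the gap is large: a 340-fold lower number from compound 1 to compound 3 (2.53 log units; beyond the scatter). Against compound 2 the step is an at least 380-fold lower number from compound 2 to compound 3 (2.58 log units; beyond the scatter), also large, while an at least 1.1-fold higher number from compound 1 to compound 2 (0.05 log units; that floor lies within the scatter) stays within the scatter.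

Compound 4, `COCc1c(F)c(N)c2c(=O)cc(-c3ccc(N)c(F)c3)oc2c1F`, differs from compound 3 in one place: methyl in place of ((dimethylamino)methyl)carbonyl on an oxygen on a saturated carbon. Among the compounds with values here, no measured step removes this group while keeping an oxygen on the saturated carbon, so the bearing steps are only those from the plain alkyl chains of compound 1 and compound 2 to compound 3. Both show that the amino ester goes with the low number. Compound 4 keeps the oxygen but loses the rest of that group, so a step back up toward the alkyl level is expected, though perhaps not the whole way. The expected step is a 58-fold higher number from compound 3 to compound 4 (1.76 log units; beyond the scatter). Compound 4 is thus estimated at 1500 nM in this assay, between 200 nM and 8000 nM.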

Compound 4, half-maximal inhibitory concentration: 46 nM
For compound 4 the middle estimate is 33-fold (1.51 log units) above the measured one; the measured number lies below the stated range.
By their numbers in this assay, from the lowest: compounds 3 and 4 (each within the scatter of the next); then compound 1. At a limit, above all of these: compound 2.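

In this assay, a 1.8-fold higher number from compound 3 to compound 4 (0.25 log units; within the scatter), so at this position the low number does not depend on the ((dimethylamino)methyl)carbonyl group, and the methyl ether and the amino ester cannot be told apart. The large gap to the plain alkyl chains therefore holds for both oxygen-bearing compounds, not for the amino ester alone: a 190-fold lower number from compound 1 to compound 4 (2.28 log units; beyond the scatter), and an at least 210-fold lower number from compound 2 to compound 4 (2.33 log units; beyond the scatter). Compound 2 still gives only a limit: the limit of > 10000 nM in this assay, at which 1 of the 4 values shown sits.

Going by these compounds, it remains open whether the gap follows the oxygen on the saturated carbon itself or the loss of the longer alkyl chain. A plain propyl chain or a hydroxymethyl group on the shared core would separate these two readings.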